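The source may report more compounds than this note shows. Statements on the series, on what has been measured and on what is new or still open speak of the compounds shown alone.

- compound 1 `CCC(=O)O[C@@H](/C(C)=C/[C@@H](C)c1oc(CC)c(C)c(=O)c1C)[C@H](C)[C@@H](OC(=O)CC(C)C)[C@@H](C)c1oc([C@@H](C)[C@@H](O)CC)c(C)c(=O)c1C` gives 21000 nM
- compound 2 `CCc1oc([C@H](C)/C=C(\C)[C@H](OC(C)=O)[C@H](C)[C@@H](OC(=O)CC(C)C)[C@@H](C)c2oc([C@@H](C)[C@H](CC)OC(C)=O)c(C)c(=O)c2C)c(C)c(=O)c1C` gives 32000 nM

Both compounds were tested in a functional assay on U-373MG ATCC cells (Homo sapiens) for inhibition, read by MTT assay, with a stated time of 72 h; on this read-out higher numbers stand for weaker inhibition and lower numbers for stronger inhibition. There, compound 2 at 32000 nM stands level with compound 1 at 21000 nM within the usual scatter of repeated measurements, so the two cannot be ranked.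

Compound 3 `CCC(=O)O[C@@H](/C(C)=C/[C@@H](C)c1oc(CC)c(C)c(=O)c1C)[C@H](C)[C@@H](OC(=O)CC(C)C)[C@@H](C)c1oc([C@@H](C)[C@H](CC)OC(C)=O)c(C)c(=O)c1C` differs from compound 2 in one place only. The change is methyl in place of hydrogen on a saturated chain carbon bound to a carbonyl carbon and in words it is methyl in place of hydrogen on a saturated chain carbon bound to a carbonyl carbon, which turns acetoxy to propanoyloxy.

Within the data shown here, no two measured compounds differ in just one place, so the data give no direct size for a step of this kind. Among the measured compounds shown here, with only two close numbers to go on, and with a single methyl as the whole change, no step beyond the scatter is expected in this assay and no direction can be firmly expected. The estimated 1.3-fold lower number from compound 2 to compound 3 (0.11 log units; within the scatter) is therefore expected to stay within the scatter. For compound 3 the estimated value is 25000 nM with an expected range from 12000 nM to 50000 nM until a measurement settles the matter.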

Compound 3, half-maximal inhibitory concentration: 9000 nM
Beside the measured number, compound 3's estimate is 2.8-fold (0.44 log units) above it; the whole stated range lies above it.
By their numbers in this assay, from the lowest: compound 3; then compounds 1 and 2 (each within the scatter of the next).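

In this assay, turning acetoxy into propanoyloxy, a single methyl in place of hydrogen on a saturated chain carbon bound to a carbonyl carbon, gives a 3.6-fold lower number from compound 2 to compound 3 (0.55 log units; beyond the scatter) and shows that this place responds to even so small an addition, which the earlier pair could not show as it differed in more than one place. Compound 3 also gives a one-place comparison with compound 1: acetyl in place of hydrogen on an oxygen on a saturated carbon gives a 2.3-fold lower number from compound 1 to compound 3 (0.37 log units; beyond the scatter) and so shows that capping this free hydroxyl also goes with stronger inhibition. Both steps are modest, and nothing measured here accounts for either of them. From the compounds shown here alone, whether a longer chain, such as butanoyloxy, would extend the drop in the number or reverse it remains open, as does the outcome with an amine or a carboxylic acid at the same place. Going by these compounds, each change is also seen only once, so it remains open whether the same methyl or acetyl would give a similar step on a different partner within the shared core.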